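Aryl urea series: tetrazolyl to pyrazolyl swap in this assay

The source may report more compounds than this note shows. Statements on the series, on what has been measured and on what is new or still open speak of the compounds shown alone.

Measured so far:
- compound 1 `Cc1cc(C)c(NC(=O)N(Cc2cc(-c3ccccc3)cs2)C2CCCCCC2)c(C)c1`: < 1 mg/kg
- compound 2 `Cc1cc(C)c(NC(=O)N(Cc2cccc(-c3nnnn3C)c2)C2CCCCCC2)c(C)c1`: > 1 mg/kg
- compound 3 `Cc1cc(C)c(NC(=O)N(Cc2ccc(-c3cccnc3)cc2)C2CCCCCC2)c(C)c1`: 0.58 mg/kg

In a functional assay on a cell-free system (plasma) with sterol O-acyltransferase, Soat (Rattus norvegicus) as the target (a higher number here means that more compound is needed for the effect, a lower number that less compound is needed), compound 2 gives only a limit, > 1 mg/kg, and no number. Compound 1 also sits at a limit, < 1 mg/kg, so of the three values shown only compound 3, at 0.58 mg/kg, is a number. Compound 2 therefore stands at the weaker end of what is shown, by the limit of > 1 mg/kg in this assay, at which 1 of the 3 values shown sits, alone, and no step between measured compounds that differ in one place exists in this set.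

Compound 4 `Cc1cc(C)c(NC(=O)N(Cc2cccc(-c3cc[nH]n3)c2)C2CCCCCC2)c(C)c1` differs from compound 2 by 1H-pyrazol-3-yl in place of 1-methyl-1H-tetrazol-5-yl on an aromatic carbon, placed on an aromatic carbon of the six-membered aromatic ring of carbon only, meta to a large group. With compound 2 known only as a limit, no direction beyond the scatter can be read from the shown numbers; the change is taken as roughly neutral to a modest move toward the range of compound 3.

Compound 4 is expected at 1.5 mg/kg, range 0.4 mg/kg to 5 mg/kg. The step this estimate means, a step that the limit leaves unreadable from compound 2 to compound 4, is an expectation only and may again end at a limit.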

Compound 4, dose for half-maximal effect: 0.097 mg/kg
For compound 4 the middle estimate is 15-fold (1.19 log units) above the measured one; measured number outside the range, below it.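

In this assay, the group on this aromatic carbon, meta to a large group, clearly matters: 1H-pyrazol-3-yl in place of 1-methyl-1H-tetrazol-5-yl gives an at least 10-fold lower number from compound 2 to compound 4 (1.01 log units; beyond the scatter). On these data alone, compound 2 is a limit and not a number, so the full size of the step stays unknown: the limit of > 1 mg/kg in this assay, at which 1 of the 4 values shown sits. For the compounds shown here, this is the only step here between compounds that differ in one place, so the reading rests on a single pair.

The change alters the hetero atom count of the ring and brings in a hydrogen-bond donor, and the compounds shown do not separate these two differences. As far as these compounds go, how 1-methyl-1H-pyrazol-3-yl, which lacks the ring hydrogen on nitrogen, would read at this position stays open.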